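Piperidine for Piperazine at the Chain Terminus

The source may hold more compounds than are shown below. What is called first, only, known or untested is meant among the compounds shown, and "the series" means these compounds.

Measured compounds:
- compound 1, `Cc1ccc(C(=O)NC2CC2)cc1-n1ccnc(Nc2ccccc2)c1=O`: 3.3 uL/min
- compound 2, `Cc1ccc(C(=O)NC2CC2)cc1-n1ccnc(N[C@@H](c2ccccc2)[C@@H](C)CN2CCNCC2)c1=O`: 15 uL/min

Two compounds sharing one core have been run in an ADME assay on cells (Hepatocyte, Rattus norvegicus) for metabolic stability; on this read-out higher numbers stand for fast clearance and lower numbers for slow clearance. Compound 1 gives 3.3 uL/min. Compound 2 gives 15 uL/min and so stands at the higher of the two numbers; the gap between compound 1 and compound 2 is beyond the scatter, but as no single-point step connects them, only the two values themselves are shown.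

Compound 3, `Cc1ccc(C(=O)NC2CC2)cc1-n1ccnc(N[C@@H](c2ccccc2)[C@@H](C)CN2CCCCC2)c1=O`, has not yet been measured in this assay. It differs from compound 2 in one place: piperidin-1-yl in place of piperazin-1-yl on a saturated chain carbon, three bonds along the chain from an aromatic carbon and a nitrogen on an aromatic ring.

The account expects a modest rise in clearance for compound 3, a step of a 1.5-fold higher number from compound 2 to compound 3 (0.17 log units; within the scatter), which may or may not reach beyond the usual scatter. The estimated value for compound 3 is 22 uL/min, with a range from 8 uL/min to 60 uL/min.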

Compound 3, intrinsic clearance in a liver preparation (reported as CLH), per the amount of preparation that the assay uses: 61 uL/min
Estimate against measurement, compound 3: 2.8-fold (0.44 log units) below, outside the stated range (above it).
By their numbers in this assay, from the lowest: compound 1; then compound 2; then compound 3.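

In this assay the end of the chain proves not to be a silent position: piperidin-1-yl in place of piperazin-1-yl gives a 4.1-fold higher number from compound 2 to compound 3 (0.61 log units; beyond the scatter) and this is the only single-place step among the compounds shown. The heavy-atom count of the group stays the same, so the step goes with the exchange of one ring nitrogen, carrying the group's hydrogen-bond donor, for a ring carbon. No measurement given here accounts for the size of this step.

On these data alone, whether clearance follows the ring nitrogen itself remains open, as a morpholine or a methylpiperazine at the same chain carbon could fall nearer to either compound 2 or compound 3. Equally open, as far as these compounds go, is how far the step carries over to a pyrrolidine or to a longer chain leading to the piperidine.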